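Carbamoyl for Sulfamoyl: Solubility at Low pH

The source may report more compounds than this note shows. Statements on the series, on what has been measured and on what is new or still open speak of the compounds shown alone.

Compound 1 `COc1ccc(-c2cc(-c3cccc(S(C)(=O)=O)c3)cnc2N)cn1`: in a physicochemical assay for solubility, read by nephelometry, measured as kinetic solubility, at pH 2 (on this read-out higher numbers stand for higher solubility and lower numbers for lower solubility), compound 1 gives > 100 ug/mL, a limit of the assay.
Compound 2 `COc1ccc(-c2cc(-c3ccc(S(N)(=O)=O)cc3)cnc2N)cn1`: in this assay compound 2 gives > 100 ug/mL, likewise a limit.
Compound 3 `COc1ccc(-c2cnc(N)c(-c3ccc(OC)nc3)c2)cn1`: in this assay compound 3 gives > 100 ug/mL, also a limit.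

Within the data shown here, compound 2 thus stands at the limit of > 100 ug/mL in this assay, at which 3 of the 3 values shown sit, and no measured compound sets it apart from the others. Compound 4 `COc1ccc(-c2cc(-c3ccc(C(N)=O)cc3)cnc2N)cn1` differs from compound 2 by carbamoyl in place of sulfamoyl on an aromatic carbon. Among the measured compounds shown here, no step between measured compounds covers this change, so no direction can be read from the measured values; the expectation is a step of no size beyond the scatter in this assay. The estimate for compound 4 in this assay is 150 ug/mL, with a range from 60 ug/mL to 400 ug/mL. This expected value corresponds to a step that the limit leaves unreadable from compound 2 to compound 4.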

Compound 4, solubility: > 100 ug/mL
Compound 4: no number, only a limit (the forecaster's own chance of this, stated with the estimate: 75%); the middle value does not contradict the limit.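

Among these compounds, compound 2 and compound 4 both sit at a limit in this assay, so no step between them can be read: the limit of > 100 ug/mL in this assay, at which 4 of the 4 values shown sit.

The compounds shown leave open how far carbamoyl and sulfamoyl differ on an aromatic carbon in this assay.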